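From 4-bromophenyl to 2-iodophenyl on a carbonyl carbon

A few compounds are considered here, and "the series" means these few. Any claim that something is new, unique, unknown or untested is made for them only; others in the source may bear on it.

- Compound 1 `COc1cc2ncnc(Nc3ccc(NC(=O)c4ccccc4C)cc3)c2cc1OC` gives 21000 nM
- Compound 2 `COc1cc2ncnc(Nc3ccc(NC(=O)c4ccccc4F)cc3)c2cc1OC` gives 11000 nM
- Compound 3 `COc1cc2ncnc(Nc3ccc(NC(=O)c4ccc(Br)cc4)cc3)c2cc1OC` gives 43000 nM

In a functional assay on MCF7 cells (Homo sapiens) for inhibition, read by MTT assay (on this read-out higher numbers stand for weaker inhibition and lower numbers for stronger inhibition), compound 3 has the highest number of the three, 43000 nM, which makes it the weakest inhibitor here. Compound 4 `COc1cc2ncnc(Nc3ccc(NC(=O)c4ccccc4I)cc3)c2cc1OC` differs from it by one change: 2-iodophenyl in place of 4-bromophenyl on a carbonyl carbon. Among the compounds with values here, two measured steps bear on this: a 2.0-fold higher number from compound 1 to compound 3 (0.31 log units; beyond the scatter), with 4-bromophenyl replacing 2-methylphenyl, and a 3.9-fold higher number from compound 2 to compound 3 (0.59 log units; beyond the scatter), with 4-bromophenyl replacing 2-fluorophenyl. Both are modest and point the same way. Fluoro in place of methyl gave a 1.9-fold lower number from compound 1 to compound 2 (0.28 log units; within the scatter). Within the data shown here, no 2-iodophenyl compound has been measured, so the swap back is only expected to lower the number modestly. The expected change in this assay is a 2.7-fold lower number from compound 3 to compound 4 (0.43 log units; beyond the scatter). The estimate for compound 4 is 16000 nM, with an expected range from 7000 nM to 36000 nM.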

Compound 4, half-maximal inhibitory concentration: 37000 nM
For compound 4 the middle estimate is 2.3-fold (0.36 log units) below the measured one; measured number outside the range, above it.
By their numbers in this assay, from the lowest: compounds 2, 1, 4 and 3 (each within the scatter of the next, the first and the last beyond it).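

In this assay the swap to 2-iodophenyl gives a 1.2-fold lower number from compound 3 to compound 4 (0.07 log units; within the scatter) and so does not separate these two aromatic groups, while a 1.8-fold higher number from compound 1 to compound 4 (0.25 log units; within the scatter) also stays within the usual scatter. Iodo and fluoro, however, are not interchangeable on this ring: a 3.4-fold higher number from compound 2 to compound 4 (0.53 log units; beyond the scatter) shows that carrying a halogen does not by itself give the lower number. No measurement here explains this gap.

As far as these compounds go, whether an amine or a carboxylic acid on this ring would lower the number remains open. So does how 4-iodophenyl would compare with 2-iodophenyl.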